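The source may report more compounds than this note shows. Statements on the series, on what has been measured and on what is new or still open speak of the compounds shown alone.

Working notes on the series. Compound 1 `COc1ccccc1NC(=S)N/N=C1\C(=O)Nc2ccccc21` and compound 2 `CN1C(=O)/C(=N\NC(=S)Nc2ccccc2)c2ccccc21` share one core and differ at the ends. In an ADME assay on RD cells (Homo sapiens) for cytotoxicity (on this read-out lower numbers stand for higher toxicity in this test and higher numbers for lower toxicity in this test), compound 1 reports only a limit, > 25000 nM. Compound 2 likewise reports only a limit in this assay, > 25000 nM. Compound 2 thus stands at the limit of > 25000 nM in this assay, at which 2 of the 2 values shown sit, with no number to set it against. Compound 3 `O=C1/C(=N\NC(=S)Nc2ccccc2)c2ccccc2N1c1ccccc1` differs from compound 2 by phenyl in place of methyl on an amide-type nitrogen in a ring. Going by the values given here, no measured step covers this change; the step of a number no higher from compound 2 to compound 3 (the limit leaves the size open) is expected to stay within the scatter. Compound 3 is estimated at 25000 nM, with a range of 8000 nM to 60000 nM.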

Compound 3, half-maximal cytotoxic concentration: > 25000 nM
Compound 3 ended at the assay's limit (the forecaster's own chance of this, stated with the estimate: 65%); the middle value sits exactly at the limit.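

No step can be read from compound 2 to compound 3, because both report only a limit in this assay: the limit of > 25000 nM in this assay, at which 3 of the 3 values shown sit.

The compounds shown leave open whether phenyl in place of methyl on an amide-type nitrogen in a ring changes the read-out at all.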